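The source may report more compounds than this note shows. Statements on the series, on what has been measured and on what is new or still open speak of the compounds shown alone.

Three compounds share one core and differ only in the aromatic ring attached to the amide carbonyl. Compound 1 `O=C(Nc1cccc(-c2oc3cc(-c4ccc(F)cc4)ccc3c(=O)c2O)c1)c1ccccc1F` gives 4410 nM in a functional assay on A549 cells (Homo sapiens) for antiproliferative activity, read by CCK-8 assay, with a stated time of 72 h; on this read-out higher numbers stand for weaker inhibition and lower numbers for stronger inhibition. Compound 2 `COc1ccccc1C(=O)Nc1cccc(-c2oc3cc(-c4ccc(F)cc4)ccc3c(=O)c2O)c1` gives 11700 nM, and compound 3 `O=C(Nc1cccc(-c2oc3cc(-c4ccc(F)cc4)ccc3c(=O)c2O)c1)c1ccc(C(F)(F)F)cc1` gives 19400 nM, which is the highest of the three numbers, meaning the weakest inhibition of cell growth seen so far. The step from compound 1 to compound 3 was a 4.4-fold higher number from compound 1 to compound 3 (0.64 log units; beyond the scatter), while the step from compound 2 to compound 3 was a 1.7-fold higher number from compound 2 to compound 3 (0.22 log units; within the scatter).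

Compound 4 `Cc1cc(C(=O)Nc2cccc(-c3oc4cc(-c5ccc(F)cc5)ccc4c(=O)c3O)c2)ccc1F` has not yet been measured. The change from compound 3 is 4-fluoro-3-methylphenyl in place of 4-(trifluoromethyl)phenyl on a carbonyl carbon. The most relevant comparison is compound 1, whose ring also carries a single fluorine rather than a trifluoromethyl group and which gave 4410 nM; that earlier step, a 4.4-fold higher number from compound 1 to compound 3 (0.64 log units; beyond the scatter), suggests that returning to a fluorinated ring could lower the number. The ring in compound 4 is not the same as that of compound 1, and the step is expected to be smaller. Compound 4 is estimated at 9000 nM, with a likely range from 3500 nM to 25000 nM, corresponding to an expected step of a 2.2-fold lower number from compound 3 to compound 4 (0.33 log units; beyond the scatter).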

Compound 4, half-maximal inhibitory concentration: 11500 nM
The estimate for compound 4 lay 1.3-fold (0.11 log units) below the measured number; low and high end bracket the measured number.
By their numbers in this assay, from the lowest: compound 1; then compounds 4, 2 and 3 (each within the scatter of the next).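

Putting 4-fluoro-3-methylphenyl in place of 4-(trifluoromethyl)phenyl on the carbonyl carbon gives, in this assay, a 1.7-fold lower number from compound 3 to compound 4 (0.23 log units; within the scatter) and so cannot be told apart from repeat-measurement noise. Measured against the 2-methoxyphenyl ring, the new ring gives a 1.0-fold lower number from compound 2 to compound 4 (0.01 log units; within the scatter) and again shows no real separation, whereas measured against the 2-fluorophenyl ring it gives a 2.6-fold higher number from compound 1 to compound 4 (0.42 log units; beyond the scatter) as a modest but real step. One fluorine on this ring is therefore not enough to match compound 1, which now stands apart from the other three compounds.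

Nothing available explains these differences. On these data alone, it also remains open whether a chlorine or an amine on this ring, or a saturated ring in its place, would bring the number closer to that of compound 1.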